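Fluoro to Bromo on the Hydrazone Phenyl: Expected Cytotoxicity

The source may hold more compounds than are shown below. What is called first, only, known or untested is meant among the compounds shown, and "the series" means these compounds.

Measured so far:
compound 1, `O=C(COc1cccc2ccccc12)N/N=C/c1ccc([N+](=O)[O-])cc1`: 14.2 ug/mL
compound 2, `O=C(COc1cccc2ccccc12)N/N=C/c1ccccc1Cl`: 62.7 ug/mL
compound 3, `O=C(COc1cccc2ccccc12)N/N=C/c1ccc(F)cc1`: 71.6 ug/mL

These three compounds share one core and differ only in the substituted phenyl ring attached to the hydrazone carbon. In an ADME assay on HEL cells (Homo sapiens) for cytotoxicity (a higher number here means that more compound is tolerated, a lower number that less compound is tolerated), compound 3 shows the highest of the three numbers, but its distance from compound 2 is a 1.1-fold higher number from compound 2 to compound 3 (0.06 log units; within the scatter), within the scatter, so the two cannot be told apart; its distance from compound 1 is a 5.0-fold higher number from compound 1 to compound 3 (0.70 log units; beyond the scatter), a modest step that does lie beyond the scatter.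

Compound 4, `O=C(COc1cccc2ccccc12)N/N=C/c1ccc(Br)cc1`, has not yet been measured in this assay. It differs from compound 3 in one place: bromo in place of fluoro on an aromatic carbon.

For the measured compounds named here, two measured steps bear on this change. The exchange of one halogenated phenyl for another, from compound 2 to compound 3, gave a 1.1-fold higher number from compound 2 to compound 3 (0.06 log units; within the scatter), within the scatter. The exchange of a nitro group for fluoro, from compound 1 to compound 3, gave a 5.0-fold higher number from compound 1 to compound 3 (0.70 log units; beyond the scatter), a modest shift. A halogen-for-halogen swap therefore is expected to produce no step beyond the scatter in this assay, perhaps a small downward drift. The step from compound 3 to compound 4 is estimated at a 1.2-fold lower number from compound 3 to compound 4 (0.08 log units; within the scatter). Compound 4 is thus expected to give about 60 ug/mL, within a range from 30 ug/mL to 120 ug/mL.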

Compound 4, half-maximal cytotoxic concentration: 100 ug/mL
Compound 4: middle estimate off by 1.7-fold (0.22 log units), on the low side; low and high end bracket the measured number.
By their numbers in this assay, from the lowest: compound 1; then compounds 2, 3 and 4 (each within the scatter of the next).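

In this assay, the change from fluoro to bromo on this aromatic carbon, para to a large group, gives a step that cannot be told from the scatter (a 1.4-fold higher number from compound 3 to compound 4 (0.15 log units; within the scatter)), so this position accepts both halogens without a measurable difference. The comparison with the 2-chlorophenyl compound also stays within the scatter (a 1.6-fold higher number from compound 2 to compound 4 (0.20 log units; within the scatter)), leaving compound 2, compound 3 and compound 4 as a group of halogenated compounds that this assay does not separate. Only the nitro compound stands apart, and the exchange of nitro for bromo gives a modest step beyond the scatter (a 7.0-fold higher number from compound 1 to compound 4 (0.85 log units; beyond the scatter)), which makes a second halogen at that place differ from nitro and shows that the earlier gap was not peculiar to fluoro; no measurement at hand gives a reason for this separation.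

The compounds shown leave open whether the separation belongs to nitro alone or would also appear with another group on this carbon, such as an amine, a methoxy group or a carboxylic acid. They also leave open whether the halogens would remain indistinguishable on a different core, as all four compounds share the same one.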